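Amide nitrogen substituent in the secoside mimic series

A few compounds are considered here, and "the series" means these few. Any claim that something is new, unique, unknown or untested is made for them only; others in the source may bear on it.

Of the compounds shown here, two carry a measured number so far. In an assay on HL-60 cells for agonist activity at vitamin D3 receptor (Homo sapiens), read by microscopy, with a stated time of 96 h (a higher number here means that more compound is needed for the effect, a lower number that less compound is needed), compound 1 `CCn1c(C(=O)N(C)CCC#N)ccc1C(CC)(CC)c1ccc(OCC(=O)C(C)(C)C)c(C)c1` gives 9800 nM and compound 2 `C#CCNC(=O)c1ccc(C(CC)(CC)c2ccc(OCC(O)C(C)(C)C)c(C)c2)n1CC` gives 240 nM. Compound 2 therefore stands with the lowest of the two numbers, and the gap to compound 1 lies beyond the scatter. These two differ in more than one place, so their two values only show the overall difference and no single step can be read from them. Compound 3 `CCn1c(C(=O)Nc2ccc(OC(F)(F)F)cc2)ccc1C(CC)(CC)c1ccc(OCC(O)C(C)(C)C)c(C)c1` is not yet measured. Its change from compound 2 is 4-(trifluoromethoxy)phenyl in place of propargyl on an amide-type nitrogen. For the measured compounds named here, no measured pair shows this kind of change, so the size of the step in this assay is not known from the data. Compound 3 is expected to give about 500 nM, within 120 nM to 2500 nM. The expected step of a 2.1-fold higher number from compound 2 to compound 3 (0.32 log units; beyond the scatter) is a modest loss, possibly within the scatter.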

Compound 3, half-maximal effective concentration: > 50000 nM
Compound 3 ended at the assay's limit; the forecaster's own chance of this, stated with the estimate: 5%; middle value at least 100-fold (2.00 log units) away from the limit.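

At this amide-type nitrogen, the substituent matters strongly in this assay: 4-(trifluoromethoxy)phenyl in place of propargyl gives an at least 200-fold higher number from compound 2 to compound 3 (2.31 log units; beyond the scatter). For the compounds shown here, this is the only single-place step so far, and it shows a sensitivity at this position that the overall gap between compound 1 and compound 2 could not assign to any one place. The reading for compound 3 is a limit and not a number, so the full size of the step remains undefined: the limit of > 50000 nM in this assay, at which 1 of the 3 values shown sits.

Going by these compounds, whether the loss goes with the phenyl ring itself or with its trifluoromethoxy group stays open from this one step. The same core carrying a plain phenyl, a benzyl or an ethyl group on this nitrogen would help separate these two possibilities.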